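Methoxy for Methyl in a Series at the Assay Limit

The compounds below may be only part of what the source reports. "The series", "measured", "known", "first", "only" and "open" are said of these compounds alone.

Of the compounds shown here, three have been read so far, and none has given a number. In a functional assay on MCF7 cells (Homo sapiens) for antiproliferative activity (on this read-out lower numbers stand for stronger inhibition and higher numbers for weaker inhibition), compound 1 `CO[C@@H]1[C@@H](O)[C@@H](O)[C@H](Oc2ccc3c(c2C)OC(=O)C(n2cc(-c4ccc(C)cc4)nn2)C3)OC1(C)C` gives > 100000 nM, which is a limit of the assay and not a number. Compound 2 `CC(=O)Oc1ccc2cc(-n3cc(-c4ccc(F)cc4F)nn3)c(=O)oc2c1C` gives > 100000 nM, which is also a limit. Compound 3 `COc1ccc(-c2cn(-c3cc4ccc(O)c(C)c4oc3=O)nn2)cc1`, which carries a 4-methoxyphenyl group, gives > 100000 nM, again a limit. Compound 1 therefore has no rank within this small set, which sits as a whole at the limit of > 100000 nM in this assay, at which 3 of the 3 values shown sit.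

Compound 4 `COc1ccc(-c2cn(C3Cc4ccc(O[C@@H]5OC(C)(C)[C@H](OC)[C@@H](O)[C@H]5O)c(C)c4OC3=O)nn2)cc1` keeps the core of compound 1 and changes one group, 4-methylphenyl to 4-methoxyphenyl. The change is methoxy in place of methyl on an aromatic carbon, para to a large group. For the measured compounds named here, no measured pair differs in only one place, so the data give no direct size for such a change. The only hint is that the 4-methoxyphenyl group of compound 3 comes with a limit, not a number. In this assay no shift beyond the scatter is therefore expected, and no direction is favoured. The expected step, a number no higher from compound 1 to compound 4 (the limit leaves the size open), reflects this. For compound 4 the estimate is 100000 nM, with an expected range of 30000 nM to 200000 nM.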

Compound 4, half-maximal inhibitory concentration: > 100000 nM
Compound 4 ended at the assay's limit; the forecaster's own chance of this, stated with the estimate: 80%; the middle value sits exactly at the limit.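

No step can be read between compound 1 and compound 4, since both stand at a limit of the assay and not at a number: the limit of > 100000 nM in this assay, at which 4 of the 4 values shown sit.

The compounds shown leave open whether the change from 4-methylphenyl to 4-methoxyphenyl has any effect in this assay, and which change to the shared core would give a number rather than a limit.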